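Fluorine on the Aryl Ring of a Spiroketal Enone Series

The source may hold more compounds than are shown below. What is called first, only, known or untested is meant among the compounds shown, and "the series" means these compounds.

Of the compounds shown here, two have been measured in a functional assay on NCI-H460 cells (Homo sapiens) for antiproliferative activity, with a stated time of 72 h; a higher number here means a weaker inhibitor, a lower number a stronger inhibitor. Compound 1 `C=CC[C@H]1C[C@]2([C@@H](C)Cc3ccc(OC)c(OC)c3)OCOC2=CC1=O` gives 260 nM, and compound 2 `C=CC[C@H]1C[C@]2([C@@H](C)Cc3ccc(OC)c(C#N)c3)OCOC2=CC1=O` gives 340 nM. Within the data shown here, compound 2 thus carries the highest of the two numbers, though its only neighbour, compound 1, sits at a distance that is within the scatter, with a step of a 1.3-fold higher number from compound 1 to compound 2 (0.12 log units; within the scatter).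

Compound 3 `C=CC[C@H]1C[C@]2([C@@H](C)Cc3cc(C#N)c(OC)cc3F)OCOC2=CC1=O` differs from compound 2 by a single change: fluoro in place of hydrogen on an aromatic carbon. Among the measured compounds shown here, no measured step involves a fluoro group entering in place of hydrogen, so the one known step, from compound 1 to compound 2, touches the same aromatic ring but a different substituent and offers only a loose guide; it was itself within the scatter. On that footing, the step is expected to be no change at the digits printed from compound 2 to compound 3 (within the scatter), with no movement beyond the scatter predicted. Compound 3 is therefore estimated at 340 nM, within a range from 140 nM to 850 nM.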

Compound 3, half-maximal inhibitory concentration: 150 nM
Estimate against measurement, compound 3: 2.3-fold (0.36 log units) above, and the stated range covers the measured number.
By their numbers in this assay, from the lowest: compounds 3, 1 and 2 (each within the scatter of the next, the first and the last beyond it).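

In this assay, the fluoro group, on an aromatic carbon ortho to a large group, meta to a methoxy group and para to a cyano group, gives a modest step beyond the scatter: a 2.3-fold lower number from compound 2 to compound 3 (0.36 log units; beyond the scatter). Among these compounds, the earlier step, a 1.3-fold higher number from compound 1 to compound 2 (0.12 log units; within the scatter), stayed within the scatter, so this position is the first place where a single change, here of one heavy atom, moves the number beyond it. Nothing at hand accounts for this shift.

Whether this step is specific to fluoro stays open, as the compounds shown offer no comparison with a chlorine atom, a methyl group or an amine on the same carbon. It is also unknown whether fluoro would give a similar step with a methoxy group in place of the cyano group, as in compound 1.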